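Extending an Alkenyl Ether Chain: Expectation for Compound 4

This account rests on a few compounds, and the source may have more. Where it says the series, first, only, none or still open, it means among the compounds named here.

Compound 1 `C=CCCCCOc1cc2ccccc2cc1-c1cnc(OCCC=C)n1C` and compound 2 `C=CCCCCOc1cc2ccccc2cc1-c1cnc(OCCCCC=C)n1C` share one core. In a functional assay on LoVo cells (Homo sapiens) for inhibition, read by colorimetric assay and MTT assay, with a stated time of 72 h (on this read-out lower numbers stand for stronger inhibition and higher numbers for weaker inhibition), compound 1 gives 25000 nM, and compound 2 gives 25000 nM. The structural change between them, (but-3-en-1-yl in place of vinyl on a saturated chain carbon, two bonds along the chain from an oxygen on an aromatic ring), produced the step of no change at the digits printed from compound 1 to compound 2 (within the scatter). Compound 3 `C=CCCOc1ncc(-c2ccccc2OC)n1C` is built on a different core; the difference between the two cores is not broken down here. In this assay compound 3 gives 24000 nM. Compound 4 `C=CCCCCOc1ncc(-c2ccccc2OC)n1C` has not been measured yet; it differs from compound 3 by but-3-en-1-yl in place of vinyl on a saturated chain carbon, two bonds along the chain from an oxygen on an aromatic ring, the same change as that from compound 1 to compound 2. Because the earlier step was no change at the digits printed from compound 1 to compound 2 (within the scatter), compound 4 is expected to show a step of a 1.0-fold higher number from compound 3 to compound 4 (0.02 log units; within the scatter). Compound 4 is therefore estimated at 25000 nM, with a range from 12000 nM to 50000 nM.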

Compound 4, half-maximal inhibitory concentration: 4000 nM
The estimate for compound 4 lay 6.3-fold (0.80 log units) above the measured number; measured number below the stated range.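

In this assay, replacing the (but-3-en-1-yl)oxy group with (hex-5-en-1-yl)oxy gave a 6.0-fold lower number from compound 3 to compound 4 (0.78 log units; beyond the scatter). Set beside the earlier step, the same change did not carry over unchanged from one core to the other: the same change on two cores in this assay, no change at the digits printed (within the scatter) from compound 1 to compound 2 and a 6.0-fold lower number (0.78 log units; beyond the scatter) from compound 3 to compound 4, 6.0-fold (0.78 log units) apart, beyond the scatter of two such steps

Within these two pairs, the result of lengthening the chain therefore depends on the core that carries it, but the data do not show which difference between the cores is responsible, and two pairs establish no rule for the wider series.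

The compounds shown leave open whether a longer alkenyl chain, a saturated hexyl chain or a chain ending in an amine would give a lower or higher number than compound 4 on the same core.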